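Aryl Groups on an Aromatic Nitrogen and Antagonist Potency

The source may hold more compounds than are shown below. What is called first, only, known or untested is meant among the compounds shown, and "the series" means these compounds.

Three compounds have been measured in a functional assay on CHO cells for antagonist activity at metabotropic glutamate receptor 1 (Mus musculus), read by FLIPR and calcium flux; a lower number here means a stronger inhibitor, a higher number a weaker inhibitor:

Compound 1 `CC(C)(C)OC(=O)N1CC=C(c2cn(-c3ccc(F)cc3)nn2)CC1` gives 31 nM.
Compound 2 `Cc1ccccc1-n1cc(C2=CCN(C(=O)OC(C)(C)C)CC2)nn1` gives 58 nM.
Compound 3 `CC(C)(C)OC(=O)N1CC=C(c2cn(-c3ccccn3)nn2)CC1` gives 150 nM.

Compound 2 stands second highest of the three numbers. Compound 1 is nearest to it, and the step of a 1.9-fold higher number from compound 1 to compound 2 (0.27 log units; within the scatter) lies within the scatter, so the two cannot be ordered. Compound 3 is furthest, with the step of a 2.6-fold higher number from compound 2 to compound 3 (0.41 log units; beyond the scatter) beyond the scatter, and the related step of a 4.8-fold higher number from compound 1 to compound 3 (0.68 log units; beyond the scatter) points the same way.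

Compound 4 `CC(C)(C)OC(=O)N1CC=C(c2cn(-c3ccncc3)nn2)CC1` differs from compound 2 in one place: pyridin-4-yl in place of 2-methylphenyl on an aromatic nitrogen. Among the measured compounds shown here, no measured step places pyridin-4-yl on this aromatic nitrogen; the only steps that bear on it are those from compound 2 and compound 1 to compound 3, where pyridin-2-yl entered and the number rose modestly. The expectation is therefore a modest rise of the same kind, a step of a 2.2-fold higher number from compound 2 to compound 4 (0.35 log units; beyond the scatter), though with uncertainty, since a different pyridinyl isomer enters. Compound 4 is estimated at 130 nM in this assay, with a range from 45 nM to 400 nM.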

Compound 4, half-maximal inhibitory concentration: 1000 nM
Compound 4: the middle estimate sits 7.7-fold (0.89 log units) below what was measured; the whole stated range lies below it.
By their numbers in this assay, from the lowest: compounds 1 and 2 (each within the scatter of the next); then compound 3; then compound 4.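

In this assay this position on the aromatic nitrogen separates the two pyridinyl isomers, since the step of a 6.7-fold higher number from compound 3 to compound 4 (0.82 log units; beyond the scatter) lies beyond the scatter, and so the place of the ring nitrogen in the entering group matters here and not only its presence. The carbon-only aryl groups stand much further from pyridin-4-yl than they did from pyridin-2-yl, with the step of a 17-fold higher number from compound 2 to compound 4 (1.24 log units; beyond the scatter) and the step of a 32-fold higher number from compound 1 to compound 4 (1.51 log units; beyond the scatter) both large, so one pyridinyl group cannot stand in for the other at this position. Nothing available explains why the two isomers part so widely.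

Where pyridin-3-yl would fall relative to these two isomers remains open. So does whether a 4-cyanophenyl or 4-methoxyphenyl group would keep the numbers of the carbon-only aryl groups or move towards that of compound 4.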